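A few compounds are considered here, and "the series" means these few. Any claim that something is new, unique, unknown or untested is made for them only; others in the source may bear on it.

Values in an assay on membranes from CHO cells for displacement of a labelled ligand from adenosine receptor A1 (Homo sapiens), read by scintillation counting, with a stated time of 60 min, tested at 1 uM (on this read-out higher numbers stand for more inhibition at the one concentration tested (going by the name of the read-out) and lower numbers for less inhibition), for the measured compounds:

compound 1 `CCCOC(=O)C1=C(C)NC(=O)NC1c1cccs1`: 43%
compound 2 `CCCOC(=O)C1=C(C)NC(=O)NC1c1ccsc1`: 44%
compound 3 `COC(=O)C1=C(C)NC(=S)NC1c1cccs1`: 1%

Compound 1 and compound 2 share one core and differ only by thiophen-3-yl in place of thiophen-2-yl on a saturated ring carbon; this step gives a number 1 percentage points higher from compound 1 to compound 2 (within the scatter), so the two ester compounds cannot be told apart in this assay. Compound 3 belongs to another core; the difference between the core of compound 3 and the core of compound 1 is not broken down here. Compound 3 sits lowest of the three, and both its gaps to compound 1 and to compound 2 are beyond the scatter.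

Compound 4 `COC(=O)C1=C(C)NC(=S)NC1c1ccsc1` is not yet measured. It differs from compound 3 by thiophen-3-yl in place of thiophen-2-yl on a saturated ring carbon, the same kind of change as from compound 1 to compound 2, though the place differs: in compound 3 the ring atom beside the changed carbon bears a methoxycarbonyl group, in compound 1 a propoxycarbonyl group. Since the earlier step was within the scatter, a step of about the same size is expected here: a number 2 percentage points higher from compound 3 to compound 4 (within the scatter), resting on a number 1 percentage points higher from compound 1 to compound 2 (within the scatter) and on compound 3 with 1%. Compound 4 is thus estimated at 3%, within 0% to 13%.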

Compound 4, a percentage reported as inhibition, at one concentration (the size of the read-out at that concentration, not a potency): 3%
Compound 4: middle estimate and measured number agree at the digits printed; low and high end bracket the measured number.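

On the core of compound 3, thiophen-3-yl in place of thiophen-2-yl gives a number 2 percentage points higher from compound 3 to compound 4 (within the scatter) in this assay. Set beside the earlier step, the change carries over between the two cores with no difference that can be read: the same change on two cores in this assay, a number 1 percentage points higher (within the scatter) from compound 1 to compound 2 and a number 2 percentage points higher (within the scatter) from compound 3 to compound 4, 1 percentage points apart, within the scatter of two such steps. Among these compounds, this does not show that the attachment point of the thiophene is without consequence across the series: only two cores are covered, at one concentration, and compound 3 and compound 4 both sit near the bottom of the read-out, where little room remains to register a drop.

From the compounds shown here alone, the difference between the two cores stays unresolved, as the methoxycarbonyl and propoxycarbonyl groups are not compared on a single core, so the separate contribution of each change to the gap between the cores remains unknown. Also open, going by these compounds, is whether the same indifference holds for other groups on that saturated ring carbon, such as furan-2-yl or phenyl, or with a longer chain such as butoxycarbonyl on the ring.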